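The source may hold more compounds than are shown below. What is called first, only, known or untested is meant among the compounds shown, and "the series" means these compounds.

Working notes on the series. Compound 1 `COC(=O)c1nc(C)n(-c2ccc(F)cc2)n1` and compound 2 `CCc1nc(C(=O)OC)nn1-c1ccc(F)cc1` share one core; compound 3 `COC(=O)c1nc(-c2ccc[nH]2)n(-c2ccc(C(F)(F)F)cc2)n1` and compound 4 `CCOC(=O)c1nc(-c2ccc[nH]2)n(-c2ccc(C(F)(F)F)cc2)n1` share another, and the difference between the two cores is not broken down here. In a functional assay on NPC-TW01 cells (Homo sapiens) for inhibition, read by MTT assay, with a stated time of 72 h (on this read-out lower numbers stand for stronger inhibition of growth and higher numbers for weaker inhibition of growth), compound 1 gives 15200 nM, and compound 2 gives 15800 nM. The change methyl in place of hydrogen on a saturated chain carbon bound to an aromatic carbon gives a 1.0-fold higher number from compound 1 to compound 2 (0.02 log units; within the scatter). For compound 3 this assay returns only a limit, > 100000 nM, which is the limit of > 100000 nM in this assay, at which 1 of the 3 values shown sits. Compound 4 is not yet measured; it differs from compound 3 by methyl in place of hydrogen on a saturated chain carbon bound to an oxygen next to a carbonyl group, the same kind of change as seen between compound 1 and compound 2, though the surroundings differ: in compound 2 the entering methyl sits on a saturated chain carbon bound to an aromatic carbon, in compound 4 on a saturated chain carbon bound to an oxygen next to a carbonyl group. For the measured compounds named here, since the one measured step of this kind, a 1.0-fold higher number from compound 1 to compound 2 (0.02 log units; within the scatter), stayed within scatter, compound 4 is expected to stay close to compound 3, that is to remain at the limit, with an expected step that the limit leaves unreadable from compound 3 to compound 4. The estimate for compound 4 in this assay is 150000 nM, ranging from 60000 nM to 400000 nM.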

Compound 4, concentration for 50% growth inhibition: 76400 nM
Estimate against measurement, compound 4: 2.0-fold (0.29 log units) above; measured number inside the range.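

In this assay, methoxycarbonyl to ethoxycarbonyl on the core of compound 3 gives an at least 1.3-fold lower number from compound 3 to compound 4 (0.11 log units; that floor lies within the scatter), and neither this step nor the earlier one shows the added methyl raising the number beyond the scatter. Set side by side, the two steps do not settle whether the change carries over unchanged from one core to the other, and they also differ in place, one on a saturated chain carbon bound to an aromatic carbon and the other on a saturated chain carbon bound to an oxygen next to a carbonyl group: the same change on two cores in this assay, a 1.0-fold higher number (0.02 log units; within the scatter) from compound 1 to compound 2 and an at least 1.3-fold lower number (0.11 log units; that floor lies within the scatter) from compound 3 to compound 4; the limit leaves it open whether they differ The true size of the newer step stays unread, and the reading for compound 3 is a limit, not a number: the limit of > 100000 nM in this assay, at which 1 of the 4 values shown sits.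

Open, as far as these compounds go, is whether methoxycarbonyl to ethoxycarbonyl on the core of compound 1 would give a step like the one on the core of compound 3. Also open, from the compounds shown here alone, is how a longer chain, a carboxylic acid or an amide in place of the ethoxycarbonyl group would read on either core.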